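This account rests on a few compounds, and the source may have more. Where it says the series, first, only, none or still open, it means among the compounds named here.

In a physicochemical assay for solubility, in phosphate buffer, at pH 6.8 (on this read-out lower numbers stand for lower solubility and higher numbers for higher solubility), compound 1 (`CC(C)(C)C(=O)C1=C(O)C(=O)N(c2ccc(-c3ccsc3)cc2)C1c1ccccc1OCCO`) gives > 50000 nM, which is a limit of the assay and not a number. Compound 2 (`COCCOc1ccccc1C1C(C(=O)C(C)(C)C)=C(O)C(=O)N1c1ccc(-c2ccsc2)cc1`), with methyl in place of hydrogen on an oxygen on a saturated carbon, gives 22800 nM. That change is an at least 2.1-fold lower number from compound 1 to compound 2 (0.34 log units; beyond the scatter). Compound 3 (`CC(C)C(=O)C1=C(O)C(=O)N(c2ccc(-c3ccsc3)cc2)C1c1ccccc1OCCO`) departs from compound 1 elsewhere: hydrogen in place of methyl on a saturated chain carbon bound to a carbonyl carbon and two saturated chain carbons, or tert-butyl to isopropyl. Within the data shown here, the only measured step, an at least 2.1-fold lower number from compound 1 to compound 2 (0.34 log units; beyond the scatter), also exchanges methyl and hydrogen, but in the opposite sense and at another place, so it offers only a loose guide. The expected change is a step that the limit leaves unreadable from compound 1 to compound 3, which would be none beyond the scatter. For compound 3 the estimate is 55000 nM, with an expected range from 25000 nM to 120000 nM.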

Compound 3, solubility: > 50000 nM
Compound 3: no number, only a limit; the forecaster's own chance of this, stated with the estimate: 60%; the middle value does not contradict the limit.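

In this assay no step can be read from compound 1 to compound 3, as each of the two stands at a limit of the assay and not at a number: the limit of > 50000 nM in this assay, at which 2 of the 3 values shown sit. The compounds shown leave open whether tert-butyl to isopropyl changes this read-out at all.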